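Exchanging an Aryl Group on an Amide-Type Nitrogen

This account rests on a few compounds, and the source may have more. Where it says the series, first, only, none or still open, it means among the compounds named here.

Compound 2 `COc1cc(-c2nn(-c3cccc(NC(=O)Nc4ccc(Cl)c(Cl)c4)c3)cc2-c2ccncc2)ccc1Cl` carries a dichlorinated aryl group on one amide-type nitrogen. For the measured compounds named here, in a functional assay on 786-0 cells (Homo sapiens) for inhibition, read by sulforhodamine B assay, with a stated time of 48 h (a higher number here means a weaker inhibitor of growth, a lower number a stronger inhibitor of growth), compound 2 gives 1310 nM, the lower of the two numbers measured so far. Compound 1 `O=C(Nc1cccc(-n2cc(-c3ccncc3)c(-c3ccc(Cl)c(O)c3)n2)c1)Nc1cccc(C(F)(F)F)c1` differs from it in more than one place and gives 4690 nM in this assay, a gap beyond the usual scatter; with two parts changed at once, it cannot show what either part alone does. Compound 3 `COc1cc(-c2nn(-c3cccc(NC(=O)Nc4cccc(C(F)(F)F)c4)c3)cc2-c2ccncc2)ccc1Cl` has not yet been measured. It differs from compound 2 by 3-(trifluoromethyl)phenyl in place of 3,4-dichlorophenyl on an amide-type nitrogen. Going by the values given here, no measured pair isolates this change, so the expectation leans on compound 1, whose value of 4690 nM also comes with the trifluoromethylphenyl group, pointing toward weaker inhibition. Compound 3 is therefore expected to give 2600 nM, within a range from 1000 nM to 6500 nM. This estimate means a step of a 2.0-fold higher number from compound 2 to compound 3 (0.30 log units; within the scatter), expected to be modest and toward weaker growth inhibition.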

Compound 3, concentration for 50% growth inhibition: 1280 nM
The estimate for compound 3 lay 2.0-fold (0.31 log units) above the measured number; measured number inside the range.
By their numbers in this assay, from the lowest: compounds 3 and 2 (each within the scatter of the next); then compound 1.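

The aryl exchange on this amide-type nitrogen in this assay gives a 1.0-fold lower number from compound 2 to compound 3 (0.01 log units; within the scatter) and so 3-(trifluoromethyl)phenyl and 3,4-dichlorophenyl cannot be told apart here. Compound 3 also forms a single-change pair with compound 1: methyl in place of hydrogen on an oxygen on an aromatic ring gives a 3.7-fold lower number from compound 1 to compound 3 (0.56 log units; beyond the scatter) and so, unlike the aryl exchange, this change clearly shifts the number. Nothing available gives a reason for either result.

As far as these compounds go, both aryl groups compared on the nitrogen are substituted phenyl rings, so it remains open how an unsubstituted phenyl, a pyridine ring or a cyclohexyl group would behave there. On the oxygen, only hydrogen and methyl are shown, leaving a longer chain such as ethyl open.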